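A few compounds are considered here, and "the series" means these few. Any claim that something is new, unique, unknown or untested is made for them only; others in the source may bear on it.

Compound 2 `COc1ccc(CNc2nc3cc(N)cc(N)c3nc2-c2ccccc2)cc1OC` gives 39800 nM in a functional assay on NCI-H23 cells (Homo sapiens) for inhibition, read by sulforhodamine B assay, with a stated time of 48 h; a higher number here means a weaker inhibitor of growth, a lower number a stronger inhibitor of growth. Compound 1 `Nc1cc(N)c2nc(-c3ccccc3)c(NCc3ccc(Cl)c(Cl)c3)nc2c1` gives 27500 nM in this assay; the two numbers lie within the scatter of each other, the step being a 1.4-fold higher number from compound 1 to compound 2 (0.16 log units; within the scatter). Compound 3 `COc1cc(CNc2nc3cc(N)cc(N)c3nc2-c2ccccc2)cc(OC)c1OC` is not yet measured; it differs from compound 2 by methoxy in place of hydrogen on an aromatic carbon. Within the data shown here, the only measured step, a 1.4-fold higher number from compound 1 to compound 2 (0.16 log units; within the scatter), exchanges the whole aromatic substituent on the saturated chain carbon and is within the scatter; no step adds a single methoxy group, so the change in compound 3 has no direct precedent. Because the step of a 1.4-fold higher number from compound 1 to compound 2 (0.16 log units; within the scatter) stayed within the scatter, the added methoxy in compound 3 is expected to produce no step beyond the scatter either, a 1.0-fold higher number from compound 2 to compound 3 (0.00 log units; within the scatter). Compound 3 is therefore estimated at 40000 nM in this assay, with a range from 15000 nM to 100000 nM.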

Compound 3, concentration for total growth inhibition: 17000 nM
Estimate against measurement, compound 3: 2.4-fold (0.37 log units) above; the range from low to high includes it.
By their numbers in this assay, from the lowest: compounds 3, 1 and 2 (each within the scatter of the next, the first and the last beyond it).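

In this assay, among these compounds, the added methoxy gives the only step beyond the scatter, a 2.3-fold lower number from compound 2 to compound 3 (0.37 log units; beyond the scatter), so this aromatic carbon, ortho to a methoxy group and meta to a large group, responds to a single substitution, though only modestly. The earlier step, a 1.4-fold higher number from compound 1 to compound 2 (0.16 log units; within the scatter), exchanged the whole aromatic substituent and stayed within the scatter, so it gave no sign of this response. No measurement bears on the origin of the new step, which remains unexplained.

From the compounds shown here alone, whether the step belongs to methoxy itself or would also follow from another group on the same carbon remains open; a hydroxy, a chlorine or an ethoxy there would test this. Also open, going by these compounds, is whether the step depends on the two methoxy groups already present on the ring.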